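The source may hold more compounds than are shown below. What is called first, only, known or untested is meant among the compounds shown, and "the series" means these compounds.

Measured in a functional assay on K562 cells (Homo sapiens) for cytotoxicity, read by MTT assay, with a stated time of 72 h; a lower number here means a stronger inhibitor, a higher number a weaker inhibitor
- compound 1 (`COc1ccc(Nc2ccc3ccccc3n2)cc1`) gives 30000 nM
- compound 2 (`COc1ccc(Nc2ccccn2)cc1`) gives 63000 nM
- compound 3 (`COc1ccc(Nc2cccnc2)cc1`) gives 68000 nM

Compound 1 has the lowest number of the three. Compound 2 and compound 3 both stand higher than compound 1 by more than the usual scatter, and they lie within the scatter of each other. For the measured compounds named here, all three carry the methoxy group, and no measured pair shows what a change at that group does.

Compound 4 (`Fc1ccc(Nc2ccc3ccccc3n2)cc1`) keeps the core of compound 1 and has fluoro in place of methoxy on an aromatic carbon, para to a large group (fluoro in place of methoxy on an aromatic carbon). Going by the values given here, with no measured step at this place, the expectation rests only on the narrow spread of the series, from compound 1 at 30000 nM to compound 3 at 68000 nM. No step beyond the scatter is expected in this assay, and a small rise in the number is the likelier direction if any shows. The expected change is a 1.2-fold higher number from compound 1 to compound 4 (0.07 log units; within the scatter) and stays within the scatter. For compound 4 the estimate is 35000 nM (expected range 15000 nM to 80000 nM).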

Compound 4, half-maximal inhibitory concentration: 36000 nM
Beside the measured number, compound 4's estimate is 1.0-fold (0.01 log units) below it; the measured number falls inside the stated range.
By their numbers in this assay, from the lowest: compounds 1, 4, 2 and 3 (each within the scatter of the next, the first and the last beyond it).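

In this assay, for the compounds shown here, the first measured step at this position, fluoro in place of methoxy on an aromatic carbon para to a large group, is a 1.2-fold higher number from compound 1 to compound 4 (0.08 log units; within the scatter) and so does not separate the two groups. Compounds 1, 2 and 3 all carry methoxy and could not show whether the number on the core of compound 1 depends on that group; this step shows that, for this one replacement, methoxy is not needed to keep the number within the scatter, even though the entering fluoro has fewer heavy atoms and no hydrogen-bond acceptor by the count. No accompanying measurement speaks to the reason for this result.

Going by these compounds, whether a group of another kind at this place, such as an amine, a carboxylic acid or a longer chain, would give a step beyond the scatter remains open, since one replacement does not describe the tolerance of the position. Also open, on these data alone, is whether fluoro in place of methoxy gives a similar step on the cores of compound 2 and compound 3.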